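Amide aryl variation on the shared core: compound 4

This account rests on a few compounds, and the source may have more. Where it says the series, first, only, none or still open, it means among the compounds named here.

The series shares the core of compound 1 `O=C(Nc1cccc(-c2oc3cc(-c4ccc(F)cc4)ccc3c(=O)c2O)c1)c1ccc(Cl)cc1`, which in a functional assay on GTL 16 cells for antiproliferative activity against GTL 16 cell line (Homo sapiens), read by CCK-8 assay, with a stated time of 72 h (on this read-out lower numbers stand for stronger inhibition and higher numbers for weaker inhibition), gives 9140 nM. Compound 2 `O=C(Nc1cccc(-c2oc3cc(-c4ccc(F)cc4)ccc3c(=O)c2O)c1)c1ccc(F)cc1F` gives 9640 nM, a step of a 1.1-fold higher number from compound 1 to compound 2 (0.02 log units; within the scatter). Compound 3 `O=C(Nc1cccc(-c2oc3cc(-c4ccc(F)cc4)ccc3c(=O)c2O)c1)c1ccc(Br)cc1` gives 25400 nM, the highest number of the three, reached through a 2.8-fold higher number from compound 1 to compound 3 (0.44 log units; beyond the scatter) and a 2.6-fold higher number from compound 2 to compound 3 (0.42 log units; beyond the scatter). Compound 4 `O=C(Nc1cccc(-c2oc3cc(-c4ccc(F)cc4)ccc3c(=O)c2O)c1)c1ccc(Cl)nc1` is not yet measured and differs from compound 3 by 6-chloropyridin-3-yl in place of 4-bromophenyl on a carbonyl carbon. Within the data shown here, the step of a 2.8-fold higher number from compound 1 to compound 3 (0.44 log units; beyond the scatter) bears most directly on this change, since bromo gave the higher number there; compound 4 returns to chloro but adds a ring nitrogen, for which no step is available. A modest lowering of the number toward compound 1 is therefore expected, a 2.3-fold lower number from compound 3 to compound 4 (0.36 log units; beyond the scatter). Compound 4 is estimated at 11000 nM, within 4500 nM to 28000 nM.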

Compound 4, half-maximal inhibitory concentration: 7520 nM
Beside the measured number, compound 4's estimate is 1.5-fold (0.17 log units) above it; measured number inside the range.
By their numbers in this assay, from the lowest: compounds 4, 1 and 2 (each within the scatter of the next); then compound 3.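

Read against the 4-chlorophenyl amide, the ring nitrogen and added hydrogen-bond acceptor of the 6-chloropyridin-3-yl group leave no separable change in this assay, with a 1.2-fold lower number from compound 1 to compound 4 (0.08 log units; within the scatter), and a 1.3-fold lower number from compound 2 to compound 4 (0.11 log units; within the scatter) is likewise within the scatter. Among these compounds, with a 3.4-fold lower number from compound 3 to compound 4 (0.53 log units; beyond the scatter), compound 3 stands alone among the four, so the 4-bromophenyl amide is the only group here set apart from the others. No evidence on hand accounts for this.

On these data alone, all four amide aryl groups carry halogen, so a non-halogenated aryl group remains open. An aryl group carrying an amine or a carboxylic acid would test whether this position tolerates such groups.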